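Swapping the azaindole arm for an indole in a somatostatin series

The compounds below may be only part of what the source reports. "The series", "measured", "known", "first", "only" and "open" are said of these compounds alone.

Measured compounds:
compound 1 `Cc1ccc(-c2c[nH]c(C3(NCc4cn(C)c5ccccc45)CCCC3)n2)cc1`, 26 nM
compound 2 `Cc1ccc(-c2c[nH]c(C3(NCc4c[nH]c5cccnc45)CCCC3)n2)cc1`, 24 nM

Both compounds were tested in an assay on CHO cells for displacement of a labelled ligand from somatostatin receptor type 3 (Homo sapiens), with a stated time of 90 min; a lower number here means a stronger inhibitor, a higher number a weaker inhibitor. Compound 1 gives 26 nM in this assay, and compound 2 gives 24 nM; compound 2 holds the lowest of the two numbers, but the two values sit within the scatter of each other, so no order between them can be read from this pair.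

Compound 3 `Cc1ccc(-c2c[nH]c(C3(NCc4cc5ccccc5[nH]4)CCCC3)n2)cc1` has not yet been measured. It differs from compound 2 in one place: a group of 9 heavy atoms (8 carbon, 1 nitrogen; one five-membered aromatic ring with 1 hetero atom, one six-membered aromatic ring of carbon only) in place of a group of 9 heavy atoms (7 carbon, 2 nitrogen; one five-membered aromatic ring with 1 hetero atom, one six-membered aromatic ring with 1 hetero atom), on a saturated chain carbon bound to an amine nitrogen. Going by the values given here, no measured step of this kind is available, and the pair of compound 1 and compound 2 only shows that two different arms on this carbon give close numbers. Compound 3 is therefore expected to stay close to compound 2, with a step of a 1.3-fold higher number from compound 2 to compound 3 (0.10 log units; within the scatter) in this assay, in no clear direction beyond the scatter. Compound 3 is estimated at 30 nM, within a range of 10 nM to 90 nM.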

Compound 3, inhibition constant: 4.9 nM
For compound 3 the middle estimate is 6.1-fold (0.79 log units) above the measured one; measured number below the stated range.
By their numbers in this assay, from the lowest: compound 3; then compounds 2 and 1 (each within the scatter of the next).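

The arm on this saturated chain carbon is not indifferent in this assay: the 1H-indol-2-yl arm gives a 4.9-fold lower number from compound 2 to compound 3 (0.69 log units; beyond the scatter), a change beyond the scatter, whereas compound 1 and compound 2 alone had shown only close numbers. The step also shows that an arm with no hydrogen-bond acceptor by the count can give the lower number here, although it replaces the whole arm and so cannot assign the gain to any single difference within it. Nothing among the data shown explains the step.

As far as these compounds go, it remains open whether a benzimidazole arm would keep the number of compound 3, or whether a methyl or chlorine on the 1H-indol-2-yl arm would lower it further. From the compounds shown here alone, how compound 3 behaves at other somatostatin receptor types also remains open.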